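Changing the aryl group on the carbonyl carbon

The source may hold more compounds than are shown below. What is called first, only, known or untested is meant among the compounds shown, and "the series" means these compounds.

Values in an ADME assay on MT4 cells (Homo sapiens) for cytotoxicity, read by MTT assay (on this read-out lower numbers stand for higher toxicity in this test and higher numbers for lower toxicity in this test), so far:
Compound 1 `O=C1c2ccccc2C(=O)N1CCOC(=S)N(C(=O)c1ccccc1[N+](=O)[O-])c1ccc(Cl)cc1` gives 21000 nM 
Compound 2 `O=C1c2ccccc2C(=O)N1CCOC(=S)N(C(=O)c1ccc(F)cc1F)c1ccc(Cl)cc1` gives 52000 nM 

Compound 2 holds the higher of these two numbers, and its gap to compound 1 lies beyond the scatter. Compound 3 `O=C1c2ccccc2C(=O)N1CCOC(=S)N(C(=O)c1c(Cl)cccc1Cl)c1ccc(Cl)cc1` has not yet been measured and differs from compound 2 as follows: 2,6-dichlorophenyl in place of 2,4-difluorophenyl on a carbonyl carbon with 2,6-dichlorophenyl in place of 2,4-difluorophenyl on a carbonyl carbon. For the measured compounds named here, one measured step bears on this change, 2,4-difluorophenyl in place of 2-nitrophenyl at that same place: a 2.5-fold higher number from compound 1 to compound 2 (0.39 log units; beyond the scatter) and no other step is available. Going by the values given here, no measured compound carries 2,6-dichlorophenyl, so the direction is uncertain, though a small drop is expected. The expected change is a 1.3-fold lower number from compound 2 to compound 3 (0.11 log units; within the scatter) and would stay within the scatter. Compound 3 is estimated at 40000 nM with an expected range from 17000 nM to 95000 nM in this assay overall.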

Compound 3, half-maximal cytotoxic concentration: 20000 nM
Beside the measured number, compound 3's estimate is 2.0-fold (0.30 log units) above it; measured number inside the range.
By their numbers in this assay, from the lowest: compounds 3 and 1 (each within the scatter of the next); then compound 2.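

In this assay the aryl group on the carbonyl carbon moves the number in both directions: 2,6-dichlorophenyl in place of 2,4-difluorophenyl gives a 2.6-fold lower number from compound 2 to compound 3 (0.41 log units; beyond the scatter) and so removes the gain seen earlier with 2,4-difluorophenyl. 2,6-Dichlorophenyl in place of 2-nitrophenyl gives a 1.1-fold lower number from compound 1 to compound 3 (0.02 log units; within the scatter) and leaves those two groups indistinguishable here, so among the three compounds only the 2,4-difluorophenyl of compound 2 stands apart. Nothing available explains why the number shifts with these groups.

The compounds shown leave open whether 2,4-difluorophenyl stands apart for its fluorine atoms or for where they sit, which a 2,6-difluorophenyl group would test. They also leave open how an unsubstituted phenyl or a cyclohexyl group at this place would compare.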